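The compounds below may be only part of what the source reports. "The series", "measured", "known", "first", "only" and "open" are said of these compounds alone.

Of the compounds shown here, three that share one core have been measured in a functional assay on MCF7 cells (Homo sapiens) for inhibition, read by MTT assay, with a stated time of 72 h; a higher number here means a weaker inhibitor, a lower number a stronger inhibitor. Compound 1 `CC(C)n1ncc2c(C(=O)Nc3cccnc3)cccc21` carries a pyridin-3-yl group on its amide nitrogen, and in this assay compound 1 reaches the limit of > 40000 nM, which is a boundary of the measurement rather than a number. Compound 2 `CC(C)n1ncc2c(C(=O)NC3CCCC3)cccc21` has cyclopentyl in place of pyridin-3-yl on that amide nitrogen, and in this assay compound 2 likewise stops at the limit of > 40000 nM. With both values sitting at a limit, the step that the two limits leave unreadable from compound 1 to compound 2 cannot be read. Compound 3 `Cc1ccc(-n2cc(CNC(=O)c3cccc4c3cnn4C(C)C)nn2)cc1C` links the core through an amide to a larger group, and in this assay compound 3 also gives only the limit of > 40000 nM. The whole record so far is the limit of > 40000 nM in this assay, at which 3 of the 3 values shown sit.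

Compound 4 `CC(C)n1ncc2c(C(=O)NCc3cn(-c4cccc(F)c4)nn3)cccc21` differs from compound 3 in one place: 3-fluorophenyl in place of 3,4-dimethylphenyl on an aromatic nitrogen. Among the measured compounds shown here, no measured step touches this change, and the one step that was measured, a step that the two limits leave unreadable from compound 1 to compound 2, is itself unreadable. Since every value shown is the limit of > 40000 nM in this assay, at which 3 of the 3 values shown sit, compound 4 is expected to remain at that limit as well. The estimate for compound 4 in this assay is 50000 nM, with a range from 15000 nM to 200000 nM. The expected step that the limit leaves unreadable from compound 3 to compound 4 is therefore none that could be told from the scatter.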

Compound 4, half-maximal inhibitory concentration: > 40000 nM
Compound 4 ended at the assay's limit; the forecaster's own chance of this, stated with the estimate: 85%; the middle value is on the limit's open side.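

Among the compounds shown here, compound 3 and compound 4 both stop at a limit of this assay rather than at a number, so no step between them can be read. The record now rests on a single boundary: the limit of > 40000 nM in this assay, at which 4 of the 4 values shown sit. The compounds shown leave open which change to the shared core, if any, would give a measurable value in this assay.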